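Trifluoromethyl for fluoro: the step from compound 3 to compound 4

The compounds below may be only part of what the source reports. "The series", "measured", "known", "first", "only" and "open" are said of these compounds alone.

Compound 3 `Fc1ccc(C2CC(c3ccc(Cl)cc3)=NN2c2ccc(-c3ccccc3)nn2)cc1` carries a 4-fluorophenyl on the shared core. In a functional assay on Caco-2 cells (Homo sapiens) for antiproliferative activity, read by MTT assay, with a stated time of 24 h (on this read-out higher numbers stand for weaker inhibition and lower numbers for stronger inhibition), compound 3 gives > 100000 nM, which is a limit of the assay and not a number. Compound 2 `Clc1ccc(C2=NN(c3ccc(-c4ccccc4)nn3)C(c3ccc(Cl)cc3)C2)cc1` differs from compound 3 only by chloro in place of fluoro. In this assay compound 2 gives > 100000 nM, again a limit and not a number. The step that the two limits leave unreadable from compound 2 to compound 3 is therefore unreadable, both ends sitting at the limit of > 100000 nM in this assay, at which 2 of the 3 values shown sit. Among the measured compounds shown here, compound 1 `FC(F)(F)c1ccc(C2CC(c3ccccc3)=NN2c2ccc(-c3ccccc3)nn2)cc1` carries the 4-(trifluoromethyl)phenyl together with a plain phenyl, and in this assay compound 1 gives 50000 nM, the one numeric value among the measured compounds. Compound 4 `FC(F)(F)c1ccc(C2CC(c3ccc(Cl)cc3)=NN2c2ccc(-c3ccccc3)nn2)cc1` is not yet measured. The change from compound 3 to compound 4 is trifluoromethyl in place of fluoro on an aromatic carbon. For the measured compounds named here, no measured step tracks this exact change, and the only single-point step available, from compound 2 to compound 3, is hidden by the limit. What can be said is that compound 4 shares the trifluoromethyl group with compound 1, and in this assay compound 1 gives 50000 nM. On that basis no step beyond the usual scatter is expected from compound 3 to compound 4, and a renewed limit remains likely. The expected step is an at least 1.2-fold lower number from compound 3 to compound 4 (0.09 log units; that floor lies within the scatter). Compound 4 is estimated at 80000 nM in this assay, within 30000 nM to 200000 nM.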

Compound 4, half-maximal inhibitory concentration: 10000 nM
Compound 4: the middle estimate sits 8.0-fold (0.90 log units) above what was measured; measured number outside the range, below it.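

In this assay, among the compounds shown here, 4-(trifluoromethyl)phenyl in place of 4-fluorophenyl is the first change at this position to give a numeric value with the 4-chlorophenyl partner kept, a result seen in the step (an at least 10-fold lower number from compound 3 to compound 4 (1.00 log units; beyond the scatter)) and in the matching step from the chloro compound (an at least 10-fold lower number from compound 2 to compound 4 (1.00 log units; beyond the scatter)). The second aryl group also matters with the trifluoromethyl group kept, since chloro in place of hydrogen on an aromatic carbon gives a step of its own (a 5.0-fold lower number from compound 1 to compound 4 (0.70 log units; beyond the scatter)). The first two steps give only a minimum size and the step between the chloro and fluoro compounds cannot be read, since compound 2 and compound 3 are each held at a limit of the assay and not at a number: the limit of > 100000 nM in this assay, at which 2 of the 4 values shown sit.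

The compounds shown give one numeric value for each of the two trifluoromethyl compounds, so it remains open whether the order seen here would hold with other partners on the shared core. On these data alone, it also remains open how a nitrile, an amine or a carboxylic acid at this position would read against trifluoromethyl in this assay.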